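The source may report more compounds than this note shows. Statements on the series, on what has been measured and on what is new or still open speak of the compounds shown alone.

Compound 1 has the structure `O=C(CN(c1nc(Cl)nc2[nH]cnc12)C1CC1)N[C@@H](CO)C(=O)OCc1ccccc1` and in a functional assay on the whole organism (Tail, strain ICR) with Mus musculus as the target, in the tail flick test, with a stated time of 120 min, at a dose of 25 umol/kg by the oral route (a higher number here means a stronger effect of the compound at the dose given, a lower number a weaker effect), compound 1 gives 34.5%. Compound 2, `C[C@@H](O)[C@H](NC(=O)CN(c1nc(Cl)nc2[nH]cnc12)C1CC1)C(=O)OCc1ccccc1`, gives 30.7%, and compound 3, `N=C(N)NCCC[C@H](NC(=O)CN(c1nc(Cl)nc2[nH]cnc12)C1CC1)C(=O)OCc1ccccc1`, gives 10.2%. Compound 3 therefore stands lowest of the three measured compounds; the step of a number 24.3 percentage points lower from compound 1 to compound 3 (beyond the scatter) and the step of a number 20.5 percentage points lower from compound 2 to compound 3 (beyond the scatter) both lie beyond the scatter, whereas the step of a number 3.8 percentage points lower from compound 1 to compound 2 (within the scatter) does not.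

Compound 4 has the structure `O=C(CN(c1nc(Cl)nc2[nH]cnc12)C1CC1)N[C@@H](CCC(=O)OCc1ccccc1)C(=O)OCc1ccccc1`. It differs from compound 3 by a group of 10 heavy atoms (8 carbon, 2 oxygen; one six-membered aromatic ring of carbon only) in place of a group of 5 heavy atoms (2 carbon, 3 nitrogen; no ring), on a saturated chain carbon, three bonds along the chain from an amide-type nitrogen and a carbonyl carbon. The two steps that bear on this change are the ones that lead into compound 3, the step of a number 24.3 percentage points lower from compound 1 to compound 3 (beyond the scatter) and the step of a number 20.5 percentage points lower from compound 2 to compound 3 (beyond the scatter): in both, putting the group of 5 heavy atoms in place of a smaller oxygen-bearing group lowered the read-out by a modest amount. Removing that same group again is expected to reverse that loss, although the benzyloxycarbonyl entering in compound 4 is unlike anything among the measured compounds, so the size is uncertain. For compound 4 the expected step is a number 19.8 percentage points higher from compound 3 to compound 4 (beyond the scatter), an increase beyond the scatter. The estimate for compound 4 is therefore 30%, with a range from 15% to 45%.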

Compound 4, a percentage reported as activity, at one dose (the size of the read-out at that dose, not a potency): 45.9%
Estimate against measurement, compound 4: 15.9 percentage points below; the whole stated range lies below it.
By their numbers in this assay, from the lowest: compound 3; then compounds 2 and 1 (each within the scatter of the next); then compound 4.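

At this position on the side chain, the change does more than recover what compound 3 lost: the read-out is a number 35.7 percentage points higher from compound 3 to compound 4 (beyond the scatter) and is large, and compound 4 also clears the two compounds with a hydroxy-bearing side chain, with a number 15.2 percentage points higher from compound 2 to compound 4 (beyond the scatter) and a number 11.4 percentage points higher from compound 1 to compound 4 (beyond the scatter) as well. Compound 4 therefore gives the highest number of the four in this assay, which shows that the ceiling at this position had not been reached by the small hydroxy-bearing groups, and that a long side chain is compatible with a strong effect at this dose; compounds 3 and 4 both carry long side chains yet stand at opposite ends of the series, so length alone does not set the read-out. No measurement offered here explains the gain.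

Going by these compounds, whether the gain depends on the aromatic ring, the ester or the chain length stays open, and a free carboxylic acid, a primary amine or a plain butyl chain at the same place would help to separate these. These numbers also come from one dose at one time, so they say nothing about how the effect changes with dose or over time.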